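The source may hold more compounds than are shown below. What is called first, only, known or untested is meant among the compounds shown, and "the series" means these compounds.

Measured compounds:
compound 1 `CCC(=O)N1CCc2nc(C#Cc3ccccc3)sc2C1` gives 38 nM
compound 2 `O=C(C1CC1)N1CCc2nc(C#Cc3ccccc3)sc2C1` gives 290 nM
compound 3 `O=C(C1CCC1)N1CCc2nc(C#Cc3ccccc3)sc2C1` gives 370 nM

All three were tested in an assay on HEK293 cells for negative allosteric modulation of metabotropic glutamate receptor 5 (Homo sapiens), read by FLIPR, with a stated time of 1 h; on this read-out lower numbers stand for stronger inhibition and higher numbers for weaker inhibition. Compound 3 has the highest number of the three, yet its gap to compound 2 is small: the step of a 1.3-fold higher number from compound 2 to compound 3 (0.11 log units; within the scatter) lies within the scatter. Its gap to compound 1, the step of a 9.7-fold higher number from compound 1 to compound 3 (0.99 log units; beyond the scatter), is clearly beyond it.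

Compound 4 `O=C(C1CCCCC1)N1CCc2nc(C#Cc3ccccc3)sc2C1` has not yet been measured. It differs from compound 3 by one change: cyclohexyl in place of cyclobutyl on a carbonyl carbon. Within the data shown here, the steps that bear on this are those that altered the same group on the carbonyl carbon. Swapping ethyl for a ring cost potency in the steps of a 7.6-fold higher number from compound 1 to compound 2 (0.88 log units; beyond the scatter) and a 9.7-fold higher number from compound 1 to compound 3 (0.99 log units; beyond the scatter), but growing that ring from cyclopropyl to cyclobutyl changed little, as shown by the step of a 1.3-fold higher number from compound 2 to compound 3 (0.11 log units; within the scatter). Growing it further to cyclohexyl is therefore expected to give at most a small rise in the number in this assay, about a 1.6-fold higher number from compound 3 to compound 4 (0.21 log units; within the scatter). Compound 4 is estimated at 600 nM, within a range from 200 nM to 2500 nM.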

Compound 4, half-maximal inhibitory concentration: > 10000 nM
Compound 4 gave a limit, no number; the forecaster's own chance of this, stated with the estimate: 5%; middle value at least 16-fold (1.22 log units) away from the limit.
By their numbers in this assay, from the lowest: compound 1; then compounds 2 and 3 (each within the scatter of the next). At a limit, above all of these: compound 4.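

In this assay, compound 4 gives only a limit, not a number: the limit of > 10000 nM in this assay, at which 1 of the 4 values shown sits. The near-flat stretch from cyclopropyl to cyclobutyl on this carbonyl carbon therefore does not extend to cyclohexyl, with large losses seen in an at least 27-fold higher number from compound 3 to compound 4 (1.43 log units; beyond the scatter) and an at least 34-fold higher number from compound 2 to compound 4 (1.53 log units; beyond the scatter). Measured against the ethyl group, the loss is an at least 260-fold higher number from compound 1 to compound 4 (2.42 log units; beyond the scatter), so at this position a small ring size change can be silent while a further one nearly abolishes measurable activity.

The compounds shown leave open whether activity fades gradually or falls off sharply, which cyclopentyl would help to settle. They also leave open whether a six-membered ring can work here in another form, such as phenyl or tetrahydropyranyl, or whether a longer chain such as butyl fares any better.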